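The compounds below may be only part of what the source reports. "The series", "measured", "known", "first", "only" and "open" are said of these compounds alone.

Of the compounds shown here, three sharing one core have been tested in a functional assay with Mus musculus as the target; a lower number here means that less compound is needed, a higher number that more compound is needed for the effect. Compound 1, `NC(=O)Cn1c(=O)n(C2OC(CO)[C@@H](O)[C@H]2O)c2nc(N)nc(O)c21`, gives 117 uM in this assay, the highest number of the three. Compound 2, `C=CCn1c(=S)n(COCCO)c2nc(N)nc(O)c21`, gives 13 uM, and compound 3, `CCCn1c(=O)n(C2C=CC(CO)O2)c2nc(N)nc(O)c21`, gives 52 uM; both numbers sit below that of compound 1 by more than the usual scatter. No two of these compounds differ in only one place, so no single measured step connects them.

Compound 4, `CCCCn1c(=O)n(C2OC(CO)[C@@H](O)[C@H]2O)c2nc(N)nc(O)c21`, differs from compound 1 in one place: propyl in place of carbamoyl on a saturated chain carbon bound to an aromatic nitrogen. Only one hint bears on this change: compound 3, whose structure also holds a propyl chain, needs less compound than compound 1, although its other substituent differs as well. On that hint, a shift toward a lower number is expected, a 2.6-fold lower number from compound 1 to compound 4 (0.41 log units; beyond the scatter), beyond the scatter yet moderate. Compound 4 is therefore expected to give about 45 uM in this assay, most likely between 12 uM and 160 uM.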

Compound 4, concentration for half-maximal effect: 100 uM
For compound 4 the middle estimate is 2.2-fold (0.35 log units) below the measured one; the measured number falls inside the stated range.
By their numbers in this assay, from the lowest: compound 2; then compounds 3, 4 and 1 (each within the scatter of the next, the first and the last beyond it).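

In this assay, among the compounds shown here, the step from carbamoyl to propyl on a saturated chain carbon bound to an aromatic nitrogen is a 1.2-fold lower number from compound 1 to compound 4 (0.07 log units; within the scatter), the first direct reading of this position with the rest of compound 1 held fixed. The change replaces a group with one hydrogen-bond donor and one acceptor by an all-carbon group with the same count of heavy atoms, yet the number stays within the scatter, so this one swap shows no measurable change here. Nothing measured here explains why the two groups read alike.

From the compounds shown here alone, whether an amine, a carboxylic acid or a chain longer than butyl at this place would shift the number remains open. Also open, going by these compounds, is whether the same swap would read alike on the other parts seen in compound 2 and compound 3.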